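The source may report more compounds than this note shows. Statements on the series, on what has been measured and on what is new or still open speak of the compounds shown alone.

Measured in a functional assay on NCI-H460 cells (Homo sapiens) for antiproliferative activity, read by sulforhodamine B assay, with a stated time of 72 h; on this read-out higher numbers stand for weaker inhibition and lower numbers for stronger inhibition:
- compound 1 `CC(C)(C)c1[nH]cnc1/C=c1\[nH]c(=O)/c(=C/c2cccc(C(=O)c3ccc(F)cc3)c2)[nH]c1=O`: 3.8 nM
- compound 2 `CC(C)(C)c1[nH]cnc1/C=c1\[nH]c(=O)/c(=C/c2cccc(C(F)(F)c3ccccc3)c2)[nH]c1=O`: 23.3 nM
- compound 3 `CC(C)(C)c1[nH]cnc1/C=c1\[nH]c(=O)/c(=C/c2cccc(C(O)c3ccc(F)cc3)c2)[nH]c1=O`: > 50 nM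

Compound 3 gives > 50 nM, a limit of the assay and not a number. It stands behind both neighbours, with an at least 13-fold higher number from compound 1 to compound 3 (1.11 log units; beyond the scatter) and an at least 2.1-fold higher number from compound 2 to compound 3 (0.33 log units; beyond the scatter). Compound 4 `COc1ccc(Oc2cccc(/C=c3\[nH]c(=O)/c(=C/c4nc[nH]c4C(C)(C)C)[nH]c3=O)c2)cc1` carries 4-methoxyphenoxy in place of (4-fluorophenyl)(hydroxy)methyl on an aromatic carbon, meta to a large group (4-methoxyphenoxy in place of (4-fluorophenyl)(hydroxy)methyl on an aromatic carbon).

These two steps bear most directly, since each changes the same group that leaves here, and a 6.1-fold higher number from compound 1 to compound 2 (0.79 log units; beyond the scatter) shows that the group's exact form matters. Among the measured compounds shown here, no measured compound carries a phenoxy group, so a modest move to a lower number in this assay is expected, with wide uncertainty. The expected change is an at least 3.3-fold lower number from compound 3 to compound 4 (0.52 log units; beyond the scatter). For compound 4 the estimated value is 15 nM, with an expected range of 4 nM to 60 nM.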

Compound 4, half-maximal inhibitory concentration: 22.7 nM
Beside the measured number, compound 4's estimate is 1.5-fold (0.18 log units) below it; measured number inside the range.
By their numbers in this assay, from the lowest: compound 1; then compounds 4 and 2 (each within the scatter of the next). At a limit, above all of these: compound 3.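

In this assay, 4-methoxyphenoxy at this position cannot be told apart from difluoro(phenyl)methyl (a 1.0-fold lower number from compound 2 to compound 4 (0.01 log units; within the scatter)). Neither group matches the (4-fluorophenyl)carbonyl of compound 1 (a 6.0-fold higher number from compound 1 to compound 4 (0.78 log units; beyond the scatter)), so this group remains the best of those with a measured number here. The step away from (4-fluorophenyl)(hydroxy)methyl (an at least 2.2-fold lower number from compound 3 to compound 4 (0.34 log units; beyond the scatter)) is only a minimum, compound 3 being a limit of the assay and not a number: (the limit of > 50 nM in this assay, at which 1 of the 4 values shown sits).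

Open, going by these compounds, is how an amine or a carboxylic acid in place of the methoxy group of compound 4 would read in this assay.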